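A few compounds are considered here, and "the series" means these few. Any claim that something is new, unique, unknown or untested is made for them only; others in the source may bear on it.

Of the compounds shown here, three that share one core have been measured, and they differ only in the group carried on the benzyl arm. Compound 3 `CCCn1c(=O)c2nc(-c3cnn(Cc4ccccc4C)c3)[nH]c2n(CCC)c1=O` is the strongest of them: in an assay on CHO cells for displacement of a labelled ligand from adenosine receptor A1 (Homo sapiens) (a lower number here means a stronger inhibitor, a higher number a weaker inhibitor), compound 3 gives 22 nM. Compound 1 `CCCn1c(=O)c2nc(-c3cnn(Cc4cc(Cl)ccc4Cl)c3)[nH]c2n(CCC)c1=O` gives 190 nM in this assay, and compound 2 `CCCn1c(=O)c2nc(-c3cnn(Cc4cc(C(F)(F)F)ccc4Cl)c3)[nH]c2n(CCC)c1=O` gives 1200 nM. Swapping the whole 2,5-dichlorophenyl for 2-methylphenyl gave an 8.6-fold lower number from compound 1 to compound 3 (0.94 log units; beyond the scatter), and the corresponding swap from 2-chloro-5-(trifluoromethyl)phenyl gave a 55-fold lower number from compound 2 to compound 3 (1.74 log units; beyond the scatter); within the halogenated pair, the change a 6.3-fold higher number from compound 1 to compound 2 (0.80 log units; beyond the scatter) shows that a single group on that ring can move the number well beyond the scatter.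

Compound 4 `CCCn1c(=O)c2nc(-c3cnn(Cc4ccccc4OC)c3)[nH]c2n(CCC)c1=O` differs from compound 3 by methoxy in place of methyl on an aromatic carbon. For the measured compounds named here, no measured step exchanges methyl for methoxy, so the three steps bear on it only indirectly: they show that the ring on the benzyl arm matters, and that a methyl-bearing ring did best so far. A small change on that ring is therefore expected to stay close to compound 3, and the step from compound 3 to compound 4 is estimated as a 2.0-fold higher number from compound 3 to compound 4 (0.31 log units; beyond the scatter), a slight weakening. Compound 4 is expected to give about 45 nM, with a range from 12 nM to 170 nM.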

Compound 4, inhibition constant: 59 nM
Estimate against measurement, compound 4: 1.3-fold (0.12 log units) below; low and high end bracket the measured number.
By their numbers in this assay, from the lowest: compound 3; then compound 4; then compound 1; then compound 2.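

In this assay, methoxy in place of methyl on this aromatic carbon, ortho to a large group, gave a 2.7-fold higher number from compound 3 to compound 4 (0.43 log units; beyond the scatter) and so counted as a real change, which shows that this position distinguishes between two small groups and that adding an oxygen with its hydrogen-bond acceptor did not improve the number. The methoxy ring still kept most of the lead held by the methyl ring, with a 3.2-fold lower number from compound 1 to compound 4 (0.51 log units; beyond the scatter) against the dichlorinated ring and a 20-fold lower number from compound 2 to compound 4 (1.31 log units; beyond the scatter) against the ring carrying chloro and trifluoromethyl, so among these four compounds both rings with a single group gave lower numbers than both rings with two groups, and none goes against this order. No separate measurement is available to explain why methyl and methoxy differ, or why the two-group rings gave higher numbers.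

The compounds shown leave open how a hydroxyl, an amine or a longer chain such as ethoxy would behave on the same aromatic carbon. They also leave open whether methoxy would still trail methyl on a ring that also carries a chloro group.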